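Extending Compound 1 with a Trifluoromethyl Group

A few compounds are considered here, and "the series" means these few. Any claim that something is new, unique, unknown or untested is made for them only; others in the source may bear on it.

Three compounds share one core and differ only in a single substituent on the aromatic ring attached to it: compound 1 `COc1ccc(-c2nnc(NC(=O)/C=C/c3ccccc3)s2)cc1`, compound 2 `O=C(/C=C/c1ccccc1)Nc1nnc(-c2ccc(Br)cc2)s1` and compound 3 `Cc1ccc(-c2nnc(NC(=O)/C=C/c3ccccc3)s2)cc1`. In a functional assay on MCF7 cells (Homo sapiens) for antiproliferative activity, read by MTT assay, with a stated time of 48 h (a lower number here means a stronger inhibitor, a higher number a weaker inhibitor), compound 1 gives 0.78 ug/mL, compound 2 gives 1.5 ug/mL and compound 3 gives 1.19 ug/mL. The number for compound 1 is the lowest of the three, yet the steps to the others stay small: a 1.9-fold higher number from compound 1 to compound 2 (0.28 log units; within the scatter) and a 1.5-fold higher number from compound 1 to compound 3 (0.18 log units; within the scatter), while between the other two a 1.3-fold lower number from compound 2 to compound 3 (0.10 log units; within the scatter). Compound 4 `COc1ccc(-c2nnc(NC(=O)/C=C/c3ccc(C(F)(F)F)cc3)s2)cc1` keeps the methoxy of compound 1 and alters the second aromatic ring instead: trifluoromethyl in place of hydrogen on an aromatic carbon. Going by the values given here, none of the measured steps concerns that ring; each involves the methoxy, bromo or methyl side and each lies within the scatter, so they offer no direct guide to the new group and show only that small changes elsewhere leave the number much where it was. With nothing to lean on, the expectation for compound 4 is a number near that of compound 1, a 1.0-fold higher number from compound 1 to compound 4 (0.01 log units; within the scatter). Compound 4 is therefore estimated at 0.8 ug/mL, within 0.35 ug/mL to 1.9 ug/mL.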

Compound 4, half-maximal inhibitory concentration: 0.79 ug/mL
Compound 4: the middle estimate sits 1.0-fold (0.01 log units) above what was measured; measured number inside the range.
By their numbers in this assay, from the lowest: compounds 1, 4, 3 and 2 (each within the scatter of the next).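

In this assay, going by these compounds alone, the second aromatic ring, which none of the earlier steps touched, now has a step of its own: trifluoromethyl in place of hydrogen, on an aromatic carbon para to a large group, gives a 1.0-fold higher number from compound 1 to compound 4 (0.01 log units; within the scatter). Within the data shown here, the earlier compounds showed only that exchanges on the methoxy side leave the number within the scatter; this step shows the same for the other ring, where a group of 4 heavy atoms enters in place of a hydrogen atom. No evidence on hand speaks to why the number holds here.

Only one group at one place on this ring is shown, so it stays open whether an amine, a carboxylic acid or a longer chain there would leave the number where it is. From the compounds shown here alone, it is also open whether trifluoromethyl would do the same alongside the bromo of compound 2 or the methyl of compound 3.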